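Expecting little change from compound 1 to compound 4

The compounds below may be only part of what the source reports. "The series", "measured", "known", "first", "only" and "open" are said of these compounds alone.

- compound 1 `COc1cc(-c2nc3ccccc3s2)ccc1OCC(=O)NNC(O)CN(C)CC(=O)O`: 3030 nM
- compound 2 `CC[C@H](C)[C@H](NCC(=O)NNC(=O)COc1ccc(-c2nc3ccccc3s2)cc1OC)C(=O)O`: 3540 nM
- compound 3 `CC[C@H](C)[C@@H](NCC(=O)NNC(=O)COc1ccc(-c2nc3ccccc3s2)cc1OC)C(=O)O`: 3990 nM

These three compounds were tested in a functional assay on HepG2 cells (Homo sapiens) for inhibition, read by MTT assay, with a stated time of 3 days; a higher number here means a weaker inhibitor, a lower number a stronger inhibitor. There, compound 1 at 3030 nM stands level with the other two, since its value lies within the usual scatter of both.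

The next compound to be measured is compound 4 `COc1cc(-c2nc3ccccc3s2)ccc1OCC(=O)NNC(=O)CN1CCC[C@H]1C(=O)O`, which keeps the core of compound 1 and changes only the chain: ((2-carboxypyrrolidin-1-yl)methyl)carbonyl in place of 2-((carboxymethyl)(methyl)amino)-1-hydroxyethyl on an amine nitrogen. In words, ((2-carboxypyrrolidin-1-yl)methyl)carbonyl takes the place of 2-((carboxymethyl)(methyl)amino)-1-hydroxyethyl on an amine nitrogen.

Going by the values given here, one measured step bears on this change, and only in part. That step is a 1.1-fold higher number from compound 2 to compound 3 (0.05 log units; within the scatter), and it rests on (the fact that compounds 2 and 3 differ only in the configuration as drawn). It speaks to the defined stereocentre that enters with compound 4, and its small size suggests that this stereocentre alone should matter little. No measurement covers the five-membered non-aromatic ring. Still, compound 1 at 3030 nM stays level with compound 2 at 3540 nM despite their different chains, so no change beyond the scatter is expected in this assay.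

The expected step is a 1.2-fold higher number from compound 1 to compound 4 (0.06 log units; within the scatter). For compound 4 the estimated value is 3500 nM, with an expected range from 1700 nM to 7000 nM.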

Compound 4, half-maximal inhibitory concentration: 2650 nM
Estimate against measurement, compound 4: 1.3-fold (0.12 log units) above; measured number inside the range.
By their numbers in this assay, from the lowest: compounds 4, 1, 2 and 3 (each within the scatter of the next).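

In this assay, ((2-carboxypyrrolidin-1-yl)methyl)carbonyl on an amine nitrogen whose other neighbour is an amide-type nitrogen leaves compound 4 level with compound 1, the step being a 1.1-fold lower number from compound 1 to compound 4 (0.06 log units; within the scatter). Going by these compounds alone, the five-membered non-aromatic ring, which no earlier compound carried, thus stands level with the open chains, since with 2-carboxypyrrolidin-1-yl in place of (1-carboxy-2-methylbutyl)amino the steps are a 1.5-fold lower number from compound 3 to compound 4 (0.18 log units; within the scatter) and a 1.3-fold lower number from compound 2 to compound 4 (0.13 log units; within the scatter). Within the data shown here, compound 4 also carries a defined stereocentre on that ring, while the only reading on configuration at this end of the molecule still comes from a single pair: the fact that compounds 2 and 3 differ only in the configuration as drawn.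

The compounds shown leave open whether the opposite configuration at the ring stereocentre of compound 4 would read the same, and whether any group at this place can move the number beyond the scatter. On these data alone, all four end in a carboxylic acid, so how an ester, a primary amide or a six-membered piperidine ring would read here also remains open.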